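Swapping the Aryl Ketone Ring for a Pentafluorophenyl Group

This account rests on a few compounds, and the source may have more. Where it says the series, first, only, none or still open, it means among the compounds named here.

Compound 2 `O=C(/C(=C\c1ccc([N+](=O)[O-])c(O)c1)SCc1ccc(Br)cc1)c1cc(Cl)ccc1O` gives 10000 nM in a functional assay on DU-145 cells (Homo sapiens) for inhibition, read by trypan blue exclusion, with a stated time of 96 h (a lower number here means a stronger inhibitor of growth, a higher number a weaker inhibitor of growth), level with its nearest neighbour compound 1 `O=C(/C(=C\c1ccc([N+](=O)[O-])c(O)c1)SCc1ccc(Br)cc1)c1ccc(Br)cc1`, which gives 10000 nM in this assay. The step of no change at the digits printed from compound 1 to compound 2 (within the scatter) stays within the scatter. Compound 3 `O=C(/C(=C\c1ccc([N+](=O)[O-])c(O)c1)SCc1ccc(Br)cc1)c1c(F)c(F)c(F)c(F)c1F` differs from compound 2 by 2,3,4,5,6-pentafluorophenyl in place of 5-chloro-2-hydroxyphenyl on a carbonyl carbon. Going by the values given here, the one measured step that bears on this change, also a swap of the ring on the carbonyl carbon, produced no movement in this assay. Compound 3 is therefore expected to show no change at the digits printed from compound 2 to compound 3 (within the scatter), nothing beyond the scatter. The estimate for compound 3 is 10000 nM, expected between 4000 nM and 25000 nM.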

Compound 3, concentration for 50% growth inhibition: 10000 nM
Estimate against measurement, compound 3: no gap at the digits printed, within the range that was stated.
By their numbers in this assay, from the lowest: compounds 1, 2 and 3 (each within the scatter of the next).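

In this assay the 2,3,4,5,6-pentafluorophenyl group gives no change at the digits printed from compound 2 to compound 3 (within the scatter) and no change at the digits printed from compound 1 to compound 3 (within the scatter) on the carbonyl carbon. This position has now taken three different rings with no step beyond the scatter, and the loss of the one hydrogen-bond donor of the 5-chloro-2-hydroxyphenyl group leaves the read-out flat. Nothing available explains this result. As far as these compounds go, whether a ring bearing an amine or a carboxylic acid at this carbonyl carbon would move the value remains open, as does the effect of any change elsewhere on the shared core.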